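Swapping one sulfonyl group on a cytotoxic pair

The source may report more compounds than this note shows. Statements on the series, on what has been measured and on what is new or still open speak of the compounds shown alone.

In a functional assay on HCT-116 cells (Homo sapiens) for cytotoxicity, read by resazurin assay, with a stated time of 48 h (on this read-out higher numbers stand for an effect only at larger amounts of compound and lower numbers for an effect already at smaller amounts), compound 1 (`COc1ccc(S(=O)(=O)Nc2ccc(-c3nc4cc(NS(=O)(=O)c5ccc(OC)cc5)ccc4o3)cc2)cc1`) gives 12000 nM and compound 2 (`O=S(=O)(Nc1ccc(-c2nc3cc(NS(=O)(=O)c4ccc(Br)cc4)ccc3o2)cc1)c1ccc(Br)cc1`) gives 11000 nM as its value. These two numbers lie within the usual scatter of repeated measurements, so compound 1 stands level with compound 2 and neither can be ranked over the other.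

Compound 3 (`COc1ccc(S(=O)(=O)Nc2ccc3oc(-c4ccc(NS(=O)(=O)c5cc(Br)ccc5OC)cc4)nc3c2)cc1`) has not been measured yet. Going from compound 1 to compound 3, the shared core stays and 5-bromo-2-methoxyphenyl comes in place of 4-methoxyphenyl on a sulfonyl sulfur (5-bromo-2-methoxyphenyl in place of 4-methoxyphenyl on a sulfonyl sulfur) while the other sulfonamide is left as it was. Within the data shown here, no measured pair shows this exact change, so the expectation rests on thin evidence. Among the measured compounds shown here, the one guide is compound 2, whose 11000 nM stays within the scatter of compound 1 despite its different sulfonyl groups. In this assay the expected step is a 1.3-fold lower number from compound 1 to compound 3 (0.12 log units; within the scatter) and lies within the scatter, so no real change is foreseen. Compound 3 is therefore estimated to give 9000 nM with a likely span from 3000 nM to 25000 nM as its range.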

Compound 3, half-maximal effective concentration: 12000 nM
Estimate against measurement, compound 3: 1.3-fold (0.12 log units) below, and the stated range covers the measured number.
By their numbers in this assay, from the lowest: compounds 2, 1 and 3 (each within the scatter of the next).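

In this assay, putting 5-bromo-2-methoxyphenyl in place of 4-methoxyphenyl on a sulfonyl sulfur gives no change at the digits printed from compound 1 to compound 3 (within the scatter), and this is the first step shown in which the compounds differ in only one place. It shows that, in this assay, this sulfonyl position accepts a ring carrying bromine and a differently placed methoxy group with no change that can be told apart from the scatter of repeated measurements. No measurement available here explains why the read-out stays level.

Since the bromine and the new methoxy position arrive together, the step cannot show what either would do alone, and two changes that each looked silent on their own could still be offsetting one another. It also leaves open whether a different kind of group on this ring, such as an amine or a carboxylic acid, would move the number beyond the scatter, and whether the same swap at the other sulfonamide would behave in the same way.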